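The source may hold more compounds than are shown below. What is called first, only, known or untested is meant among the compounds shown, and "the series" means these compounds.

Compound 2 `CSCC(=O)N1CCN(c2nc(=O)c3cc(C(F)(F)F)cc([N+](=O)[O-])c3s2)CC1` is one of three compounds built on a shared core, differing only in the group carried on the carbonyl. In an ADME assay on Vero cells (Chlorocebus sabaeus) for cytotoxicity, read by MTT assay, with a stated time of 72 h (on this read-out higher numbers stand for lower toxicity in this test and lower numbers for higher toxicity in this test), compound 2 gives > 125000 nM, which is a limit of the assay and not a number. Compound 1 `O=C(CC1CCCCC1)N1CCN(c2nc(=O)c3cc(C(F)(F)F)cc([N+](=O)[O-])c3s2)CC1` gives > 125000 nM in this assay, also a limit. Compound 3 `CC(C)(C)C(=O)N1CCN(c2nc(=O)c3cc(C(F)(F)F)cc([N+](=O)[O-])c3s2)CC1` gives > 125000 nM in this assay, again a limit. Because all three values sit at the limit of > 125000 nM in this assay, at which 3 of the 3 values shown sit, the steps a step that the two limits leave unreadable from compound 1 to compound 2, a step that the two limits leave unreadable from compound 1 to compound 3 and a step that the two limits leave unreadable from compound 2 to compound 3 have no readable size. Compound 4 `CCCCC(=O)N1CCN(c2nc(=O)c3cc(C(F)(F)F)cc([N+](=O)[O-])c3s2)CC1` has not yet been measured. It differs from compound 2 in one place: propyl in place of methylsulfanyl on a saturated chain carbon bound to a carbonyl carbon. The measured steps that bear on this change are the three exchanges on the same carbonyl, and none of them shows a size, so no direction can be drawn from them. Compound 4 is therefore expected to sit at the same limit in this assay, with a step that the limit leaves unreadable from compound 2 to compound 4 expected to lie within the scatter. The estimate for compound 4 is 150000 nM, within 60000 nM to 400000 nM.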

Compound 4, half-maximal cytotoxic concentration: > 125000 nM
Compound 4: no number, only a limit; the forecaster's own chance of this, stated with the estimate: 85%; the middle value does not contradict the limit.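

No step to compound 4 from compound 1, compound 2 or compound 3 can be read in this assay, since all four values are limits of the assay and not numbers: the limit of > 125000 nM in this assay, at which 4 of the 4 values shown sit.

The compounds shown leave open at what concentration any of these four becomes toxic to the cells, and whether the groups on the carbonyl differ in this respect.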